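Benzyl to 4-Chlorophenyl: Estimating the Next Compound

This account rests on a few compounds, and the source may have more. Where it says the series, first, only, none or still open, it means among the compounds named here.

Measured so far:
Compound 1 `O=c1nc2oc(C3CC3)c(C#CC3CC3)c2cn1Cc1cn(Cc2ccccc2)nn1` gives 4590 nM in a functional assay on CFPAC-1 cells (Homo sapiens) for antiproliferative activity, read by MTT assay, with a stated time of 72 h; a higher number here means a weaker inhibitor, a lower number a stronger inhibitor.
Compound 2 `O=c1c(I)cn(Cc2cn(Cc3ccccc3)nn2)c(=O)n1Cc1cn(Cc2ccccc2)nn1` gives only a limit, > 100000 nM, in this assay.

Within the data shown here, compound 1 therefore stands as the only real number in this assay; the other value is a limit (the limit of > 100000 nM in this assay, at which 1 of the 2 values shown sits). Compound 3 `O=c1nc2oc(C3CC3)c(C#CC3CC3)c2cn1Cc1cn(-c2ccc(Cl)cc2)nn1` differs from compound 1 by 4-chlorophenyl in place of benzyl on an aromatic nitrogen. Among the measured compounds shown here, no measured pair shows this change, so only a step within the usual scatter is expected. The estimate for compound 3 in this assay is 4500 nM, between 1500 nM and 13000 nM, an expected step of a 1.0-fold lower number from compound 1 to compound 3 (0.01 log units; within the scatter).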

Compound 3, half-maximal inhibitory concentration: 35400 nM
For compound 3 the middle estimate is 7.9-fold (0.90 log units) below the measured one, outside the stated range (above it).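

In this assay, 4-chlorophenyl in place of benzyl on the aromatic nitrogen gives a 7.7-fold higher number from compound 1 to compound 3 (0.89 log units; beyond the scatter), so this position responds to the change. The two groups have the same count of heavy atoms and each has one six-membered aromatic ring, yet they are not interchangeable here. No measurement shown explains this step.

The compounds shown leave open whether the step follows from losing the carbon of benzyl outside its ring or from gaining chlorine. Phenyl or 4-chlorobenzyl at this position would separate the two.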